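This account rests on a few compounds, and the source may have more. Where it says the series, first, only, none or still open, it means among the compounds named here.

Of the compounds shown here, three sharing one core have been tested in a functional assay on HepG2 cells (Homo sapiens) for inhibition, read by MTT assay, with a stated time of 48 h (a higher number here means a weaker inhibitor, a lower number a stronger inhibitor), and none of them gives a number. Compound 1 `CCSc1nnc(-c2cc(OC)c(OC)c(OC)c2)n1-c1ccc(N(C)C)cc1` reads > 60000 nM, which is a limit. Compound 2 `COc1cc(-c2nnc(SCc3ccc(C)cc3)n2-c2ccc(N(C)C)cc2)cc(OC)c1OC` reads > 60000 nM, also a limit. Compound 3 `COc1ccc(C(=O)CSc2nnc(-c3cc(OC)c(OC)c(OC)c3)n2-c2ccc(N(C)C)cc2)cc1O` reads > 100000 nM, again a limit. Compound 3 therefore stands with no measured potency, only a limit, like the other two.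

The next compound, compound 4 `CCOC(=O)CSc1nnc(-c2cc(OC)c(OC)c(OC)c2)n1-c1ccc(N(C)C)cc1`, puts ethoxy in place of 3-hydroxy-4-methoxyphenyl on a carbonyl carbon. The measured steps that bear on this change all alter the same chain on the sulfur: a step that the two limits leave unreadable from compound 1 to compound 2, a step that the two limits leave unreadable from compound 1 to compound 3 and a step that the two limits leave unreadable from compound 2 to compound 3. None of these has a readable size, so they offer no direction to carry forward. With three different groups there all ending at a limit, no change beyond the usual scatter is expected in this assay. The expected step is an at least 1.2-fold lower number from compound 3 to compound 4 (0.09 log units; that floor lies within the scatter), and another limit is quite likely. Compound 4 is estimated at 80000 nM, with an expected range from 25000 nM to 200000 nM.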

Compound 4, half-maximal inhibitory concentration: > 60000 nM
Compound 4 was reported as a limit; the forecaster's own chance of this, stated with the estimate: 70%; the middle value is on the limit's open side.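

In this assay compound 4 gives > 60000 nM, which is a limit. Compared with compound 1, compound 2 and compound 3, also limits, it gives no step that can be read. Whether any group on the sulfur chain changes potency stays open: the compounds shown give no measured number.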